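Adding chloro to an inactive methyl compound

The source may report more compounds than this note shows. Statements on the series, on what has been measured and on what is new or still open speak of the compounds shown alone.

- compound 1 `Cc1ccc2c(c1)OCC(=O)N2Cc1cn(Cc2ccccc2)nn1`: > 100000 nM (a limit)
- compound 2 `COc1ccc2c(c1)OCC(=O)N2Cc1cn(Cc2ccccc2)nn1`: 9200 nM

In a functional assay on Hep 3B2 cells (Homo sapiens) for cytotoxicity, read by MTT assay, with a stated time of 6 days (on this read-out higher numbers stand for weaker inhibition and lower numbers for stronger inhibition), compound 1 gives only a limit, > 100000 nM, so no number fixes its place. That is the whole record for it: the limit of > 100000 nM in this assay, at which 1 of the 2 values shown sits. Compound 2 does give a number. For the measured compounds named here, the one measured step is an at least 10-fold lower number from compound 1 to compound 2 (1.03 log units; beyond the scatter), with methoxy in place of methyl on an aromatic carbon.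

Compound 3 `Cc1cc2c(cc1Cl)N(Cc1cn(Cc3ccccc3)nn1)C(=O)CO2` keeps the methyl of compound 1 and differs by chloro in place of hydrogen on an aromatic carbon. The step to compound 2 changed the methyl itself, so it bears on this change only loosely. It does show, at 9200 nM for compound 2, that one change to the shared core can bring a number within reach. A lower number is therefore expected, in a smaller drop, and the limit may well persist. The expected step is an at least 3.3-fold lower number from compound 1 to compound 3 (0.52 log units; beyond the scatter). For compound 3 the estimate is 30000 nM, with an expected range from 6000 nM to 100000 nM.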

Compound 3, half-maximal inhibitory concentration: > 100000 nM
Compound 3 gave a limit, no number (the forecaster's own chance of this, stated with the estimate: 35%); middle value at least 3.3-fold (0.52 log units) from the limit.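

For the compounds shown here, compound 3, like compound 1, gives only a limit in this assay, so no step between the two can be read: the limit of > 100000 nM in this assay, at which 2 of the 3 values shown sit. The compounds shown leave open whether chloro in place of hydrogen on an aromatic carbon changes the read-out of compound 1 at all.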